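The source may report more compounds than this note shows. Statements on the series, on what has been measured and on what is new or still open speak of the compounds shown alone.

Working notes on the series. Compound 1 `CC(=O)c1ccc(Nc2cc(C)nc(-c3cccnc3)n2)cc1` and compound 2 `CC(=O)c1cccc(Nc2cc(C)nc(-c3cccnc3)n2)c1` share the same atoms joined differently; the difference between the two cores is not broken down here. In a physicochemical assay for solubility, in phosphate buffer (on this read-out higher numbers stand for higher solubility and lower numbers for lower solubility), compound 1 gives 94000 nM, and in this assay compound 2 gives 95000 nM, two numbers that lie within the scatter of each other. Compound 3 `CC(=O)c1ccc(Nc2cc(C)nc(-c3cccnc3)n2)cc1F` carries fluoro in place of hydrogen on an aromatic carbon relative to compound 1; in this assay compound 3 gives 32000 nM, so that a 2.9-fold lower number from compound 1 to compound 3 (0.47 log units; beyond the scatter).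

Compound 4 `CC(=O)c1cc(Nc2cc(C)nc(-c3cccnc3)n2)ccc1F` carries fluoro in place of hydrogen on an aromatic carbon relative to compound 2. Within the data shown here, this is the same kind of change as the one from compound 1 to compound 3, fluoro in place of hydrogen on an aromatic carbon, ortho to an acetyl group in both cases, but the surroundings of the place are not identical: in compound 3 the fluorine sits meta to a large group, in compound 4 para to a large group. Only one measured instance of this kind of change exists among these compounds, so no wider pattern can be claimed.

Among the measured compounds shown here, for compound 4 a step of about a 2.9-fold lower number from compound 2 to compound 4 (0.46 log units; beyond the scatter) in this assay is expected, set beside the earlier one, because compound 2 starts from 95000 nM and the single measured instance gave a 2.9-fold lower number from compound 1 to compound 3 (0.47 log units; beyond the scatter). Compound 4 is therefore estimated at about 33000 nM in this assay, with a likely span from 14000 nM to 75000 nM, the width reflecting that the place differs from the measured case.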

Compound 4, solubility: 40000 nM
Beside the measured number, compound 4's estimate is 1.2-fold (0.08 log units) below it, within the range that was stated.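

In this assay, fluoro in place of hydrogen on an aromatic carbon gives a 2.4-fold lower number from compound 2 to compound 4 (0.38 log units; beyond the scatter), which runs in the same direction as a 2.9-fold lower number from compound 1 to compound 3 (0.47 log units; beyond the scatter), so the change carries from the core of compound 1 to the core of compound 2 with a lower number in both pairs and with each step beyond the scatter. Among these compounds, this rests on only two pairs, both with the fluoro ortho to an acetyl group, so it supports no general rule for other cores or for fluoro at other places on the ring. The compounds shown offer no measurement that would explain the lower number in either pair.

Still open, as far as these compounds go, is whether an amine or a carboxylic acid in place of the same hydrogen, ortho to the acetyl group, would move the number in this assay in the same direction as fluoro does. Also open, from the compounds shown here alone, is whether the fluoro step would keep its direction and approximate size if a longer chain took the place of the acetyl group, or if a morpholine ring took the place of the methyl group on the shared core.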